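A few compounds are considered here, and "the series" means these few. Any claim that something is new, unique, unknown or untested is made for them only; others in the source may bear on it.

Working notes on the series. In an in vitro functional assay on 1321-N1 cells for agonist activity at P2Y purinoceptor 4 (Homo sapiens) (a higher number here means that more compound is needed for the effect, a lower number that less compound is needed), compound 1 `CCCc1cc(=O)n([C@@H]2O[C@H](COP(=O)(O)OP(=O)(O)OP(=O)(O)O)[C@@H](O)[C@H]2O)c(=O)[nH]1` reaches only the assay limit > 100000 nM and gives no number. Compound 2 `Cc1cc(=O)n([C@@H]2O[C@H](COP(=O)(O)OP(=O)(O)O)[C@@H](O)[C@H]2O)c(=O)[nH]1` likewise returns only the limit > 100000 nM in this assay. Among the measured compounds shown here, compound 3 `CCCc1cc(=O)n([C@@H]2O[C@H](COP(=O)(O)OP(=O)(O)O)[C@@H](O)[C@H]2O)c(=O)[nH]1` also stands at the limit > 100000 nM in this assay, so every value so far sits at the limit of > 100000 nM in this assay, at which 3 of the 3 values shown sit. The change to compound 4 `CCCc1cc(=O)n([C@@H]2O[C@H](COP(=O)(O)O)[C@@H](O)[C@H]2O)c(=O)[nH]1` is a hydrogen atom in place of a group of 4 heavy atoms (3 oxygen, 1 phosphorus; no ring), on an oxygen. The measured steps that bear on it are a step that the two limits leave unreadable from compound 1 to compound 3, which removes a group of the same kind, and a step that the two limits leave unreadable from compound 2 to compound 3; both are unreadable, so neither size nor direction can be taken from them. Compound 4 is therefore expected to give about 100000 nM in this assay, between 30000 nM and 300000 nM, most likely again only as a limit. The expected step of a number no higher from compound 3 to compound 4 (the limit leaves the size open) is accordingly no step beyond the scatter.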

Compound 4, half-maximal effective concentration: > 100000 nM
Compound 4 ended at the assay's limit; the forecaster's own chance of this, stated with the estimate: 85%; the middle value lies on the limit itself.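

No step can be read from compound 3 or compound 1 to compound 4, because each pair rests on limits only: the limit of > 100000 nM in this assay, at which 4 of the 4 values shown sit.

The compounds shown leave open whether any change on the shared core gives a number rather than a limit in this assay.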